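A nitrooxyphenyl hydrazone replaces the bromohydroxyphenyl arm

This account rests on a few compounds, and the source may have more. Where it says the series, first, only, none or still open, it means among the compounds named here.

Of the compounds shown here, three sharing one core have been measured in a functional assay on MKN-45 cells (Homo sapiens) for cytotoxicity, read by MTT assay, with a stated time of 72 h; on this read-out lower numbers stand for stronger inhibition and higher numbers for weaker inhibition. Compound 1 `CN(C)CCn1cnnc1-c1cc(Oc2ccc(NC(=O)N/N=C/c3cccc(O)c3)cc2F)ccn1` gives 1370 nM. Compound 2 `CN(C)CCn1cnnc1-c1cc(Oc2ccc(NC(=O)N/N=C/c3ccc(O)cc3)cc2F)ccn1` gives 820 nM, and compound 3 `CN(C)CCn1cnnc1-c1cc(Oc2ccc(NC(=O)N/N=C/c3ccc(O)c(Br)c3)cc2F)ccn1` gives 1860 nM. Compound 3 has the highest number of the three: a 1.4-fold higher number from compound 1 to compound 3 (0.13 log units; within the scatter), while a 2.3-fold higher number from compound 2 to compound 3 (0.36 log units; beyond the scatter). Going from compound 1 to compound 2, a 1.7-fold lower number from compound 1 to compound 2 (0.22 log units; within the scatter).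

Compound 4 `CN(C)CCn1cnnc1-c1cc(Oc2ccc(NC(=O)N/N=C/c3ccccc3O[N+](=O)[O-])cc2F)ccn1` differs from compound 3 in one place: 2-(nitrooxy)phenyl in place of 3-bromo-4-hydroxyphenyl on a carbon with a double bond to nitrogen. Within the data shown here, none of the measured steps covers this change; the steps seen so far only swap the hydroxyl position or add a bromo on the phenyl ring, and all of them stay small, the largest being the one from compound 2 to compound 3. On that basis a change of the phenyl substitution is expected to move this assay only modestly, with no direction clearly favoured, so a number close to that of compound 3 is estimated. Compound 4 is therefore expected to show a 1.2-fold lower number from compound 3 to compound 4 (0.09 log units; within the scatter) in this assay, giving an estimated 1500 nM with a range from 500 nM to 5000 nM.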

Compound 4, half-maximal inhibitory concentration: 1020 nM
For compound 4 the middle estimate is 1.5-fold (0.17 log units) above the measured one; low and high end bracket the measured number.
By their numbers in this assay, from the lowest: compounds 2, 4, 1 and 3 (each within the scatter of the next, the first and the last beyond it).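

In this assay, among these compounds, the earlier compounds varied only hydroxyl and bromo substitution, whereas the 2-(nitrooxy)phenyl arm has no hydrogen-bond donors and still stays within the scatter of all three hydroxyl-bearing arms (replacing 3-bromo-4-hydroxyphenyl gives a 1.8-fold lower number from compound 3 to compound 4 (0.26 log units; within the scatter); replacing 4-hydroxyphenyl gives a 1.2-fold higher number from compound 2 to compound 4 (0.09 log units; within the scatter); replacing 3-hydroxyphenyl gives a 1.3-fold lower number from compound 1 to compound 4 (0.13 log units; within the scatter)). At this place, on the carbon with a double bond to nitrogen, a hydroxyl on the phenyl ring is therefore not needed for a number in this range. (Nothing available explains this result)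

The compounds shown leave open how an amine or a carboxylic acid on the phenyl ring would read in this assay. They also leave open whether a nitrooxy group carried on a longer chain would stay in the same range.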